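The source may report more compounds than this note shows. Statements on the series, on what has been measured and on what is new or still open speak of the compounds shown alone.

Working notes on the series sharing the core of compound 1 `Nc1ncnn2c([C@@H]3O[C@H](CO)[C@@H](O)[C@H]3O)cc(C#Cc3ccc(F)cc3)c12`. In a functional assay on HL-60 cells (Homo sapiens) for antiproliferative activity, with a stated time of 72 h (on this read-out higher numbers stand for weaker inhibition and lower numbers for stronger inhibition), compound 1 gives > 100000 nM, which is a limit of the assay and not a number. In this assay compound 2 `Nc1ncnn2c([C@@H]3O[C@H](CO)[C@@H](O)[C@H]3O)cc(-c3ccc(F)cc3)c12` gives 68300 nM and compound 3 `Nc1ncnn2c([C@@H]3O[C@H](CO)[C@@H](O)[C@H]3O)cc(-c3ccc(F)cc3F)c12` gives 99300 nM. These two numbers stand level within the scatter, as a 1.5-fold higher number from compound 2 to compound 3 (0.16 log units; within the scatter) shows, and both lie close to the limit seen for compound 1.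

Compound 4 `Nc1ncnn2c([C@@H]3O[C@H](CO)[C@@H](O)[C@H]3O)cc(-c3ccoc3)c12` has furan-3-yl in place of 2,4-difluorophenyl on an aromatic carbon.

Two measured steps at or near this place bear on the change. Fluoro in place of hydrogen gave a 1.5-fold higher number from compound 2 to compound 3 (0.16 log units; within the scatter), and 4-fluorophenyl in place of 2-(4-fluorophenyl)ethynyl gave an at least 1.4-fold lower number from compound 1 to compound 2 (0.16 log units; that floor lies within the scatter). Going by the values given here, no measured step brings in a five-membered aromatic ring, so the direction rests on little. A modest move to a lower number is expected in this assay, with a wide margin. The expected step is a 2.5-fold lower number from compound 3 to compound 4 (0.39 log units; beyond the scatter). For compound 4 the estimate is 40000 nM, with an expected range of 4000 nM to 120000 nM.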

Compound 4, half-maximal inhibitory concentration: 500 nM
Beside the measured number, compound 4's estimate is 80-fold (1.90 log units) above it, outside the stated range (below it).
By their numbers in this assay, from the lowest: compound 4; then compounds 2 and 3 (each within the scatter of the next). At a limit, above all of these: compound 1.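

In this assay, this position on the five-membered aromatic ring of the shared core proves far more sensitive than the phenyl compounds suggested, with furan-3-yl giving large steps from both of them (a 200-fold lower number from compound 3 to compound 4 (2.30 log units; beyond the scatter)) (a 140-fold lower number from compound 2 to compound 4 (2.14 log units; beyond the scatter)). Compound 1 stands at a limit of the assay, so its step gives only a floor (an at least 200-fold lower number from compound 1 to compound 4 (2.30 log units; beyond the scatter)). Adding fluoro to the phenyl ring moved the number only within the scatter, whereas exchanging the six-membered carbon ring for the five-membered ring with one hetero atom gave the first clearly lower number in the series.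

Compound 4 alone cannot separate the part played by the ring oxygen from that of the smaller ring. From the compounds shown here alone, whether thiophen-3-yl, furan-2-yl or a pyridine ring at this place would keep the low number remains open.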